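Benzyloxybenzylamine amides: chloro to fluoro on the outer ring

The compounds below may be only part of what the source reports. "The series", "measured", "known", "first", "only" and "open" are said of these compounds alone.

Measured so far:
compound 1, `NC(=O)CNCc1ccc(OCc2cccc(F)c2)cc1`: 13600 nM in an assay on mitochondria for inhibition of Amine oxidase [flavin-containing] A (Rattus norvegicus); on this read-out lower numbers stand for stronger inhibition and higher numbers for weaker inhibition
compound 2, `NC(=O)[C@H](CO)NCc1ccc(OCc2cccc(Cl)c2)cc1`: 84600 nM in this assay

Going by the values given here, compound 2 holds the higher of the two numbers in this assay, and the gap to compound 1 lies beyond the scatter; the two structures differ in more than one place, so no single step is drawn between them. Compound 3, `NC(=O)[C@H](CO)NCc1ccc(OCc2cccc(F)c2)cc1`, keeps the rest of compound 2 and changes only the halogen: fluoro in place of chloro on an aromatic carbon. Among the compounds with values here, no measured pair shows this swap on its own, so a step within the scatter is expected, leaning toward a lower number. For compound 3 the estimate is 50000 nM, range 15000 nM to 150000 nM, the expected step being a 1.7-fold lower number from compound 2 to compound 3 (0.23 log units; within the scatter).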

Compound 3, half-maximal inhibitory concentration: 100000 nM
Estimate against measurement, compound 3: 2.0-fold (0.30 log units) below, within the range that was stated.
By their numbers in this assay, from the lowest: compound 1; then compounds 2 and 3 (each within the scatter of the next).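

In this assay, with a 1.2-fold higher number from compound 2 to compound 3 (0.07 log units; within the scatter) for fluoro in place of chloro, the two halogens cannot be told apart at this aromatic carbon when hydroxymethyl is present. With a 7.4-fold higher number from compound 1 to compound 3 (0.87 log units; beyond the scatter) for hydroxymethyl in place of hydrogen, the chain carbon bound to the amine nitrogen and the carbonyl carbon emerges as a place where a single change moves the number beyond the scatter. Nothing at hand offers a reason for either step.

As far as these compounds go, whether a bromo or methoxy group on this aromatic carbon, or a longer chain in place of hydroxymethyl, would move the number remains open. Also open, from the compounds shown here alone, is whether the hydroxymethyl step holds with chloro on the aromatic ring.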